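This account rests on a few compounds, and the source may have more. Where it says the series, first, only, none or still open, it means among the compounds named here.

Working notes on the series. Compound 1 `CC(C)c1ccc(N2C(=O)C=CC2OCC(F)(F)F)cc1` gives 9570 nM in a functional assay on A549 cells (Homo sapiens) for inhibition; a higher number here means a weaker inhibitor, a lower number a stronger inhibitor. Of the two numbers shown it stands at the top, yet compound 2 `O=C1C=CC(OCC(F)(F)F)N1c1cc(F)cc(F)c1`, with 5000 nM in this assay, sits within the scatter of it, so the pair cannot be told apart. Compound 3 `O=C1C=CC(OCC(F)(F)F)N1c1ccc([N+](=O)[O-])cc1` is not yet measured; it differs from compound 1 by nitro in place of isopropyl on an aromatic carbon. Going by the values given here, no measured step covers such a swap, so the expected step of a 1.4-fold lower number from compound 1 to compound 3 (0.14 log units; within the scatter) is set close to nothing beyond the scatter. Compound 3 is estimated at 7000 nM, with a range from 2500 nM to 25000 nM.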

Compound 3, half-maximal inhibitory concentration: 3270 nM
The estimate for compound 3 lay 2.1-fold (0.33 log units) above the measured number; the range from low to high includes it.
By their numbers in this assay, from the lowest: compounds 3, 2 and 1 (each within the scatter of the next, the first and the last beyond it).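

Going by these compounds alone, at the aromatic carbon para to a large group, nitro in place of isopropyl gives a 2.9-fold lower number from compound 1 to compound 3 (0.47 log units; beyond the scatter) in this assay and is the first change to reach beyond the scatter. This position therefore responds to the group placed on it, modestly, even though the heavy-atom count stays the same and only the atoms and hydrogen-bond acceptors differ. Nothing on hand accounts for the step. Still open, going by these compounds, is how an amine, a carboxylic acid or a longer alkyl chain at this position would compare with nitro and isopropyl.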